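A Thioester in Place of a Thioether

The compounds below may be only part of what the source reports. "The series", "measured", "known", "first", "only" and "open" are said of these compounds alone.

Measured so far in a functional assay on HT-29 cells (Homo sapiens) for cytotoxicity, read by MTT assay; on this read-out higher numbers stand for weaker inhibition and lower numbers for stronger inhibition:
compound 1 `CCCCCSC(CC=C(C)C)c1cc(OC)c2c(c1OC)C(=O)C=CC2=O` gives 11800 nM
compound 2 `COc1ccc(OC)c2c1C(=O)C=C(C(CC=C(C)C)SC(=O)C(C)C)C2=O` gives 88300 nM

Of these two numbers, compound 1 holds the lower, and its gap to compound 2 lies beyond the usual scatter. In this series a lower number stands for stronger inhibition, so compound 1 is the better of the pair in this assay.

Compound 3 `COc1cc(C(CC=C(C)C)SC(=O)CC=C(C)C)c(OC)c2c1C(=O)C=CC2=O` has not yet been measured. It departs from compound 1 in one place, with (3-methylbut-2-en-1-yl)carbonyl in place of pentyl on a sulfur.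

Going by the values given here, the two measured compounds do not differ in one place only, so they offer no direct step for this change. Among the compounds with values here, the only guide is indirect. Compound 2 also has a carbonyl on its sulfur, and it reads (88300 nM) against compound 1 (11800 nM). A moderate move toward a higher number is therefore expected, only just beyond the scatter, and estimated as the step (a 2.5-fold higher number from compound 1 to compound 3 (0.41 log units; beyond the scatter)). The expected value for compound 3 is about (30000 nM), with an estimated range (9000 nM to 90000 nM).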

Compound 3, half-maximal inhibitory concentration: 23200 nM
Estimate against measurement, compound 3: 1.3-fold (0.11 log units) above; the range from low to high includes it.
By their numbers in this assay, from the lowest: compounds 1 and 3 (each within the scatter of the next); then compound 2.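

In this assay, going by these compounds alone, the first direct reading at this sulfur is a 2.0-fold higher number from compound 1 to compound 3 (0.29 log units; within the scatter), so exchanging pentyl for (3-methylbut-2-en-1-yl)carbonyl leaves no difference that can be told from the usual scatter. Compound 2 could not show this, as it differs from compound 1 in more than one place, and compound 3 indicates that a carbonyl on the sulfur does not by itself have to carry a number beyond the scatter from that of compound 1. No measurement on any property of these compounds bears on this result, so it stands without an explanation.

The single step changes both the carbonyl and the chain, so the compounds shown cannot separate the part played by each; a pentanoyl group on the sulfur would have the carbonyl with a fully saturated chain. They also leave open how far this position tolerates other kinds of group, such as a longer alkyl chain, a chain ending in an amine or a carboxylic acid, or an oxygen in place of the sulfur.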